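Cytotoxicity notes on an oxindole series: anilino for piperidinyl

This account rests on a few compounds, and the source may have more. Where it says the series, first, only, none or still open, it means among the compounds named here.

Compound 1 `CCS(=O)(=O)Nc1ccc2c(c1)/C(=C(/NC1CCN(C)CC1)c1ccccc1)C(=O)N2` is the reference point of these notes. In an ADME assay on HepG2 cells (Homo sapiens) for cytotoxicity, read by MTT assay, with a stated time of 48 h (on this read-out lower numbers stand for higher toxicity in this test and higher numbers for lower toxicity in this test), compound 1 gives > 10 uM, which is a limit of the assay rather than a number. On the values shown, compound 1 therefore sits at the limit of > 10 uM in this assay, at which 1 of the 2 values shown sits, and no finer placement is possible. Compound 2 `O=C1Nc2ccccc2/C1=C(/Nc1ccc(CN2CCCCC2)cc1)c1ccccc1` gives > 6 uM in this assay, again a limit and not a number. That value sits at the limit of > 6 uM in this assay, at which 1 of the 2 values shown sits. Going by the values given here, the two limits differ in their cut-off, so the two compounds cannot be ordered against each other, and no step between measured compounds is available.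

Compound 3 `CCS(=O)(=O)Nc1ccc2c(c1)/C(=C(/Nc1ccccc1)c1ccccc1)C(=O)N2` remains to be measured in this assay. It differs from compound 1 in one place: phenyl in place of 1-methylpiperidin-4-yl on an amine nitrogen. Among the compounds with values here, with only limits behind compound 1 and compound 2, no measured step gives a size for such a change; the working expectation is a step of no more than the scatter, with compound 3 staying in the region of the limit, as a step that the limit leaves unreadable from compound 1 to compound 3. Compound 3 is thus estimated at 15 uM in this assay, within 5 uM to 50 uM, most likely reported again only as a limit.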

Compound 3, half-maximal toxic concentration: 4.7 uM
Beside the measured number, compound 3's estimate is 3.2-fold (0.50 log units) above it; the measured number lies below the stated range.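

In this assay, phenyl in place of 1-methylpiperidin-4-yl on an amine nitrogen gives an at least 2.1-fold lower number from compound 1 to compound 3 (0.32 log units; beyond the scatter), so this substituent is a place where the read-out moves beyond the scatter, in the direction of higher toxicity in this test. Compound 3, at 4.7 uM, gives these notes their first value that is a number and not a limit, and so a measured point against which further changes on this amine nitrogen can be read. Compound 1 remains a limit, so the step gives only a minimum size: the limit of > 10 uM in this assay, at which 1 of the 3 values shown sits.

On these data alone, the full size of the step stays open, and compound 2 differs from compound 3 in more than one place, so it adds no reading of this change. Also open, as far as these compounds go, is which part of the change carries the step, the aromatic carbon ring or the departure of the ring nitrogen with its methyl group, a question that cyclohexyl or pyridyl on the same amine nitrogen could help to separate.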